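From compound 3 to compound 4: changing the amine substituent

The source may hold more compounds than are shown below. What is called first, only, known or untested is meant among the compounds shown, and "the series" means these compounds.

In a functional assay on HCT-116 cells (Homo sapiens) for cytotoxicity, read by MTT assay, with a stated time of 72 h (on this read-out higher numbers stand for weaker inhibition and lower numbers for stronger inhibition), compound 1 `CS(=O)(=O)Oc1c(C(=O)NCc2ccc(F)cc2)nc(Br)c2cccnc12` gives > 20000 nM, which is a limit. Compound 2 `O=C(NCc1ccc(F)cc1)c1nc(Br)c2cccnc2c1NCc1ccc(F)cc1` gives > 20000 nM, also a limit. Compound 3 `CN(C)CCCNc1c(C(=O)NCc2ccc(F)cc2)nc(Br)c2cccnc12` gives > 10000 nM, again a limit, so its place in the series cannot be read as a number.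

Compound 4 `N[C@H]1CC[C@H](Nc2c(C(=O)NCc3ccc(F)cc3)nc(Br)c3cccnc23)CC1` differs from compound 3 as follows: 4-aminocyclohexyl in place of 3-(dimethylamino)propyl on a nitrogen on an aromatic ring. This places 4-aminocyclohexyl in place of 3-(dimethylamino)propyl on a nitrogen on an aromatic ring.

The steps bearing on this change are a step that the two limits leave unreadable from compound 1 to compound 3 and a step that the two limits leave unreadable from compound 2 to compound 3, and neither has a readable size. No step beyond the scatter and no direction can therefore be expected in this assay. The expected step is a step that the limit leaves unreadable from compound 3 to compound 4. Compound 4 is estimated at 12000 nM, with an expected range of 4000 nM to 30000 nM.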

Compound 4, half-maximal inhibitory concentration: 7000 nM
For compound 4 the middle estimate is 1.7-fold (0.23 log units) above the measured one; low and high end bracket the measured number.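

In this assay, compound 4 is the only compound shown with a measured value on this nitrogen series, and the steps among compound 1, compound 2 and compound 3 cannot be read. Placing 4-aminocyclohexyl on this nitrogen gives an at least 1.4-fold lower number from compound 3 to compound 4 (0.15 log units; that floor lies within the scatter), so the comparison with the open-chain amine stays bounded by a limit: the limit of > 10000 nM in this assay, at which 1 of the 4 values shown sits. The other two comparisons give an at least 2.8-fold lower number from compound 2 to compound 4 (0.45 log units; beyond the scatter) and an at least 2.8-fold lower number from compound 1 to compound 4 (0.45 log units; beyond the scatter).

Whether the ring or its amine accounts for the measured value stays open. A plain cyclohexyl or a 4-hydroxycyclohexyl group would separate the two.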